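The compounds below may be only part of what the source reports. "The series", "measured", "known", "first", "only" and "open" are said of these compounds alone.

Going by the values given here, compound 1 `Cc1ccccc1C(=O)OC1(C(=O)Nc2ccc([N+](=O)[O-])cc2)CCCCC1` is the lower of the two numbers measured so far in an ADME assay on WI-38 cells (Homo sapiens) for inhibition, read by MTT assay, with a stated time of 72 h (on this read-out lower numbers stand for stronger inhibition and higher numbers for weaker inhibition), where compound 1 gives 352 nM. Among the compounds with values here, its only neighbour is compound 2 `CC(=O)OC1(C(=O)Nc2ccc([N+](=O)[O-])cc2)CCCCC1`, which in this assay gives 386 nM; the step of a 1.1-fold higher number from compound 1 to compound 2 (0.04 log units; within the scatter) lies within the scatter, so the two compounds cannot be told apart on these numbers.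

The new compound, compound 3 `O=C(OC1(C(=O)Nc2ccc([N+](=O)[O-])cc2)CCCCC1)C(O)c1ccccc1`, differs from compound 1 in one place: hydroxy(phenyl)methyl in place of 2-methylphenyl on a carbonyl carbon. The change sits on a carbonyl carbon whose other neighbours are oxygen next to a carbonyl group.

Within the data shown here, only one measured step bears on this change. Exchanging the 2-methylphenyl for methyl, in a 1.1-fold higher number from compound 1 to compound 2 (0.04 log units; within the scatter), moved the number by no more than the scatter, which suggests that what is attached to this carbonyl carbon has little say in this assay. Among the measured compounds shown here, no measured compound carries a hydroxy group at this place, so the effect of the hydrogen-bond donor that enters is unknown. Compound 3 is therefore expected to show a 1.1-fold higher number from compound 1 to compound 3 (0.03 log units; within the scatter), no step beyond the scatter. The estimate for compound 3 in this assay is 380 nM, with a range from 180 nM to 800 nM.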

Compound 3, half-maximal inhibitory concentration: 84.4 nM
Beside the measured number, compound 3's estimate is 4.5-fold (0.65 log units) above it; measured number below the stated range.
By their numbers in this assay, from the lowest: compound 3; then compounds 1 and 2 (each within the scatter of the next).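

In this assay this place on the carbonyl carbon turns out not to be indifferent: the step is a 4.2-fold lower number from compound 1 to compound 3 (0.62 log units; beyond the scatter) and, starting from the smaller group, a 4.6-fold lower number from compound 2 to compound 3 (0.66 log units; beyond the scatter) with both steps read against the same shared core. Compounds 1 and 2 had suggested that the group here hardly counted, but they show only that 2-methylphenyl and methyl cannot be told apart, whereas hydroxy(phenyl)methyl stands clearly apart from both. Nothing measured here accounts for this difference, so the step remains an observation without an explanation.

The change brings in a hydroxy group and also alters how the phenyl ring is attached, so the compounds shown cannot assign the lower number to either feature alone. A plain benzyl group would test the phenyl ring without the hydroxy group, while a methoxy group or an amine in place of the hydroxy group would show whether this particular group is needed.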